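Trading a Chloro for Hydrogen in a Cytotoxic Series

A few compounds are considered here, and "the series" means these few. Any claim that something is new, unique, unknown or untested is made for them only; others in the source may bear on it.

The two measured compounds, both read in a functional assay on HCT-15 cells (Homo sapiens) for cytotoxicity, read by sulforhodamine B assay, with a stated time of 48 h; on this read-out higher numbers stand for lower toxicity in this test and lower numbers for higher toxicity in this test:

Compound 1 `ClCc1cccc(Cn2cnc3c(Cl)nc(Cl)nc32)c1` gives > 100000 nM, which is a limit of this assay and not a number.
Compound 2 `ClCc1ccccc1Cn1cnc2nc(Cl)nc(Cl)c21` gives 950 nM.

Going by the values given here, compound 2 therefore holds the only actual number in this assay; the other value shown is a limit, as the limit of > 100000 nM in this assay, at which 1 of the 2 values shown sits, records. Nothing else places compound 2 higher or lower, so it stands alone as the reference point.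

Compound 3 `ClCc1ccccc1Cn1cnc2ncnc(Cl)c21` is the unmeasured partner. It differs from compound 2 in one place: hydrogen in place of chloro on an aromatic carbon. Among the compounds with values here, no pair of measured compounds in this set shows what removing a chloro does, so the size of the step has to be guessed from the structural change alone.

The expectation is a modest loss of cytotoxicity, a step of about a 3.2-fold higher number from compound 2 to compound 3 (0.50 log units; beyond the scatter) in this assay, probably beyond the usual scatter but not dramatic. On that basis compound 3 is estimated at 3000 nM in this assay, with a plausible range from 800 nM to 15000 nM.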

Compound 3, concentration lethal to 50% of the cells: 6160 nM
For compound 3 the middle estimate is 2.1-fold (0.31 log units) below the measured one; the measured number falls inside the stated range.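

In this assay, going by these compounds alone, hydrogen in place of chloro on the aromatic carbon between two ring nitrogen atoms gives a 6.5-fold higher number from compound 2 to compound 3 (0.81 log units; beyond the scatter), the first reading of what a change at this position does. The step runs towards lower toxicity in this test and lies beyond the scatter, yet compound 3 still gives 6160 nM, a real number and not a limit of the assay, so this chloro is not needed for a measurable reading in these cells. Nothing among the data shown offers a reason for the size of this step.

The compounds shown leave open whether an amine, a methoxy group or a fluoro at the same position would keep the reading close to that of compound 2 or move it towards that of compound 3. They also leave open whether hydrogen in place of the remaining chloro would bring a step of similar size or a very different one.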